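This account rests on a few compounds, and the source may have more. Where it says the series, first, only, none or still open, it means among the compounds named here.

Working notes on the series. In an ADME assay on MRC5 cells (Homo sapiens) for cytotoxicity, read by neutral red uptake (on this read-out lower numbers stand for higher toxicity in this test and higher numbers for lower toxicity in this test), compound 1 `O=c1[nH]c(SCc2ccccc2)nc2ccccc12` gives > 64000 nM, which is a limit of the assay and not a number. Among the measured compounds shown here, that makes the limit of > 64000 nM in this assay, at which 1 of the 2 values shown sits, the only reading available, and it belongs to compound 1.

Compound 2 `COc1ccccc1CSc1nc2ccccc2c(=O)[nH]1` has no number to place it: its entry in this assay reads "not determined" (no result reported). As far as these compounds go, its standing therefore remains open, and it cannot be ranked against compound 1.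

The next compound to be read is compound 3 `O=c1[nH]c(SCc2ccccc2[N+](=O)[O-])nc2ccccc12`. The change is nitro in place of methoxy on an aromatic carbon, ortho to a large group. The rest of the structure stays the same.

For the measured compounds named here, the series holds no measured step to show what such a change does, so the size of this one can only be expected. In this assay the expectation is a small shift or none beyond the usual scatter, with any shift toward lower numbers, meaning higher toxicity in this test. A reading reported only as a limit would fit this expectation.

For compound 3 the expected value is 50000 nM, with an estimated range of 16000 nM to 64000 nM.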

Compound 3, half-maximal cytotoxic concentration: > 64000 nM
Compound 3 ended at the assay's limit (the forecaster's own chance of this, stated with the estimate: 55%); middle value at least 1.2-fold (0.10 log units) away from the limit.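

No step can be read between compound 1 and compound 3, because each reading is a limit of the assay and not a number: the limit of > 64000 nM in this assay, at which 2 of the 3 values shown sit.

The compounds shown leave open whether nitro in place of hydrogen on an aromatic carbon shifts the reading in this assay at all, and where compound 2 stands.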